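Adding a Sulfonamide to a Potent Boronic Acid Inhibitor

The source may report more compounds than this note shows. Statements on the series, on what has been measured and on what is new or still open speak of the compounds shown alone.

Three compounds have been measured in an assay on isolated protein for inhibition of serine protease 1 (Homo sapiens); on this read-out higher numbers stand for weaker inhibition and lower numbers for stronger inhibition:
compound 1 `CC1(C)C2CC1[C@]1(C)OB([C@H](CCCN=C(N)N)NC(=O)c3ccc(-c4ccccc4)cc3)O[C@@H]1C2` gives 33 nM
compound 2 `Cc1cc(-c2ccccc2)ccc1C(=O)N[C@@H](CCCN=C(N)N)B1O[C@@H]2CC3CC(C3(C)C)[C@]2(C)O1` gives 4.2 nM
compound 3 `CC1(C)OB([C@H](CCCN=C(N)N)NC(=O)c2ccccc2)OC1(C)C` gives 70 nM

Compound 2 has the lowest number of the three and is therefore the strongest inhibitor measured: compound 1 stands nearest to it, compound 3 furthest. Compounds 1 and 2 differ in a single place, and that step, a 7.9-fold lower number from compound 1 to compound 2 (0.90 log units; beyond the scatter), is a modest but real gain. Compound 3 differs from compound 2 in more than one place, so its value shows only that it is the weaker of the two.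

Compound 4 `Cc1cc(-c2ccccc2S(=O)(=O)NC(C)(C)C)ccc1C(=O)N[C@@H](CCCN=C(N)N)B1O[C@@H]2CC3CC(C3(C)C)[C@]2(C)O1` differs from compound 2 by (tert-butyl)sulfamoyl in place of hydrogen on an aromatic carbon. For the measured compounds named here, no measured step bears directly on this change: the only step seen so far, from compound 1 to compound 2, adds a small group at a different place, whereas here a much larger group enters ortho to a large group. Going by the values given here, with no precedent, the expectation is that compound 4 stays close to compound 2, a step of a 1.1-fold lower number from compound 2 to compound 4 (0.02 log units; within the scatter), with a wide margin on either side. Compound 4 is therefore estimated at 4 nM in this assay, with a range from 1 nM to 20 nM.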

Compound 4, inhibition constant: 0.7 nM
Estimate against measurement, compound 4: 5.7-fold (0.76 log units) above, outside the stated range (below it).
By their numbers in this assay, from the lowest: compound 4; then compound 2; then compound 1; then compound 3.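

The place on the aromatic ring, ortho to a large group, holds far more than a hydrogen: in this assay, (tert-butyl)sulfamoyl, with its 8 heavy atoms, gives a 6.0-fold lower number from compound 2 to compound 4 (0.78 log units; beyond the scatter). For the compounds shown here, the only single-place change readable before this was the small methyl step, a 7.9-fold lower number from compound 1 to compound 2 (0.90 log units; beyond the scatter), made at a different place, so this is the first evidence that a much larger group can be added to the molecule at this place and still go with stronger inhibition, not weaker. Nothing measured here bears on why the number falls.

The step swaps a hydrogen for the whole group at once, so it cannot show whether the gain belongs to the sulfonyl part, to the nitrogen with its hydrogen, or to the tert-butyl end. A plain sulfamoyl group without the tert-butyl, a methylsulfonyl group or a carboxylic acid at the same place would begin to separate these parts, and the compounds shown leave all of them open.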